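Alkyl Variation on the Chain Carbon Bound to the Aromatic Nitrogen

This account rests on a few compounds, and the source may have more. Where it says the series, first, only, none or still open, it means among the compounds named here.

In a functional assay on MCF7 cells (Homo sapiens) for antiproliferative activity (a higher number here means a weaker inhibitor, a lower number a stronger inhibitor), three compounds have been measured:
compound 1, `COc1cc(Cc2nc3c(N)ncnc3n2CCCC(C)C)cc(OC)c1OC`: 69200 nM
compound 2, `CC/C=C/Cn1c(Cc2cc(OC)c(OC)c(OC)c2)nc2c(N)ncnc21`: 46800 nM
compound 3, `CCn1c(Cc2cc(OC)c(OC)c(OC)c2)nc2c(N)ncnc21`: 79400 nM

Compound 3 sits close to its two neighbours: the step of a 1.1-fold higher number from compound 1 to compound 3 (0.06 log units; within the scatter) and the step of a 1.7-fold higher number from compound 2 to compound 3 (0.23 log units; within the scatter) both lie within the scatter, so nothing separates the three compounds on these numbers. Compound 4, `COc1cc(Cc2nc3c(N)ncnc3n2CC2(C)CC2)cc(OC)c1OC`, differs from compound 3 by 1-methylcyclopropyl in place of methyl on a saturated chain carbon bound to an aromatic nitrogen. The steps that touch the same place, a 1.5-fold lower number from compound 1 to compound 2 (0.17 log units; within the scatter) and a 1.7-fold higher number from compound 2 to compound 3 (0.23 log units; within the scatter), stayed within the scatter, so the exchange of one alkyl group for another at this carbon is expected to give a step of a 1.2-fold lower number from compound 3 to compound 4 (0.09 log units; within the scatter) of no size beyond the scatter. Compound 4 is therefore estimated at 65000 nM, within a range from 30000 nM to 140000 nM.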

Compound 4, half-maximal inhibitory concentration: 112000 nM
For compound 4 the middle estimate is 1.7-fold (0.24 log units) below the measured one; the measured number falls inside the stated range.
By their numbers in this assay, from the lowest: compounds 2, 1, 3 and 4 (each within the scatter of the next, the first and the last beyond it).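

In this assay, going by these compounds alone, 1-methylcyclopropyl gives the first step at this carbon that passes the scatter (a 2.4-fold higher number from compound 2 to compound 4 (0.38 log units; beyond the scatter)). The other two steps stay within it (a 1.4-fold higher number from compound 3 to compound 4 (0.15 log units; within the scatter); a 1.6-fold higher number from compound 1 to compound 4 (0.21 log units; within the scatter)), so this ring separates compound 4 only from compound 2, the but-1-en-1-yl compound, and not from the methyl or isopentyl compounds. No measurement here gives a reason for this step. The compounds shown leave open whether an amine or a carboxylic acid on this chain carbon would move the number further than any alkyl group has.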